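Swapping Cyano for Trifluoromethyl on the Shared Core

This account rests on a few compounds, and the source may have more. Where it says the series, first, only, none or still open, it means among the compounds named here.

Compound 1 `CCc1nnc2c(C#N)c(N3CCC(c4ccccc4)CC3)ccn12` — 696 nM
Compound 2 `N#Cc1c(N2CCC(c3ccccc3)CC2)ccn2c(CC3CC3)nnc12` — 74 nM

Of the compounds shown here, two have been measured in a functional assay on CHO cells for positive allosteric modulation of metabotropic glutamate receptor 2 (Homo sapiens), read by GTPgammaS binding, with a stated time of 30 min; on this read-out higher numbers stand for an effect only at larger amounts of compound and lower numbers for an effect already at smaller amounts. Compound 1 gives 696 nM, the highest of the two numbers; its nearest neighbour is compound 2, which gives 74 nM. Among the measured compounds shown here, the single measured step, a 9.4-fold lower number from compound 1 to compound 2 (0.97 log units; beyond the scatter), comes from cyclopropyl in place of methyl on a saturated chain carbon bound to an aromatic carbon.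

Compound 3 `CCc1nnc2c(C(F)(F)F)c(N3CCC(c4ccccc4)CC3)ccn12` is not yet measured. It differs from compound 1 by trifluoromethyl in place of cyano on an aromatic carbon. For the measured compounds named here, no measured step touches this position: the step from compound 1 to compound 2 changes a different part of the molecule, so it gives no guide to what a trifluoromethyl in place of cyano does here. With nothing bearing on the change, the expectation for compound 3 is left close to the value of compound 1, with a wide range in either direction. Compound 3 is therefore estimated at 900 nM, between 250 nM and 3500 nM, which means an expected step of a 1.3-fold higher number from compound 1 to compound 3 (0.11 log units; within the scatter).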

Compound 3, half-maximal effective concentration: 116 nM
For compound 3 the middle estimate is 7.8-fold (0.89 log units) above the measured one; the whole stated range lies above it.
By their numbers in this assay, from the lowest: compounds 2 and 3 (each within the scatter of the next); then compound 1.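

In this assay this aromatic carbon proves open to change, and the nitrile is not required there for the effect: the step is a 6.0-fold lower number from compound 1 to compound 3 (0.78 log units; beyond the scatter), with trifluoromethyl in place of cyano. Here a group of 4 heavy atoms and no hydrogen-bond acceptor replaces one of 2 heavy atoms and 1 hydrogen-bond acceptor, and the number still falls beyond the scatter, so this position now has a measured step of its own alongside the one on the chain. Nothing measured on these compounds accounts for why the change lowers the number.

The compounds shown leave open whether trifluoromethyl on this aromatic carbon and cyclopropyl on the chain together give a lower number than either change alone, since each has been read only against compound 1. They also leave open how other groups on the same aromatic carbon, such as a chlorine atom, a methyl or a methoxy group, would read against the nitrile and the trifluoromethyl.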